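Dropping One Chlorine From a Dichlorophenyl Group

The source may report more compounds than this note shows. Statements on the series, on what has been measured and on what is new or still open speak of the compounds shown alone.

Compound 2, `CN1CCN(c2nc(-c3cc(Cl)ccc3Cl)nc3[nH]cnc23)CC1`, was tested in an assay on cells for displacement of a labelled ligand from adenosine receptor A1 (Homo sapiens), read by scintillation counting and radioligand binding, with a stated time of 60 min, tested at 10 uM; on this read-out higher numbers stand for more inhibition at the one concentration tested (going by the name of the read-out) and lower numbers for less inhibition. The value reported for compound 2 is a limit of the assay, > 80%. Compound 1, `Clc1ccc(-c2nc(N3CCCCC3)c3nc[nH]c3n2)cc1`, also reaches a limit, > 80%. This is the limit of > 80% in this assay, at which 2 of the 2 values shown sit, so the two cannot be ranked against each other. Compound 3, `CN1CCN(c2nc(-c3ccc(Cl)cc3)nc3[nH]cnc23)CC1`, differs from compound 2 by 4-chlorophenyl in place of 2,5-dichlorophenyl on an aromatic carbon. Among the measured compounds shown here, no measured pair differs in just one place, so the size of this step is unknown. Little movement beyond the scatter is expected, since compound 1 already carries 4-chlorophenyl and gives > 80%. Compound 3 is expected to show about 85%, within 65% to 97%. The expected step is a step that the limit leaves unreadable from compound 2 to compound 3.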

Compound 3, a percentage reported as inhibition, at one concentration (the size of the read-out at that concentration, not a potency): > 80%
Compound 3: only a limit was reported; the forecaster's own chance of this, stated with the estimate: 65%; the middle value does not contradict the limit.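

Compounds 1, 2 and 3 all give only a limit, so neither step to compound 3 can be read: the limit of > 80% in this assay, at which 3 of the 3 values shown sit.

On these data alone, whether 4-chlorophenyl or 2,5-dichlorophenyl, or 4-methylpiperazin-1-yl or piperidin-1-yl, gives more inhibition in this assay stays open.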